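Swapping a cyclic amine for an open-chain ether amine

The compounds below may be only part of what the source reports. "The series", "measured", "known", "first", "only" and "open" are said of these compounds alone.

Of the compounds shown here, two from this series have been measured so far. Compound 1 `Cc1nc(N2CCCCC2)c2nnn(-c3ccc(C(C)C)cc3Br)c2n1` gives 46 nM in an in vitro assay on 293-EBNA cells for binding affinity to corticotropin-releasing factor receptor 1 (Homo sapiens) (on this read-out lower numbers stand for stronger inhibition and higher numbers for weaker inhibition), which is the higher of the two numbers recorded. Compound 2 `CCC(CC)Nc1nc(C)nc2c1nnn2-c1c(C)cc(C)cc1C` gives 5.7 nM in this assay, and the gap between compound 1 and compound 2 lies beyond the usual scatter. For the measured compounds named here, compound 2 differs from compound 1 in several places at once, so no single structural step can be drawn from this pair.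

Compound 3 `COCC(C)(C)Nc1nc(C)nc2c1nnn2-c1ccc(C(C)C)cc1Br` keeps the core and the aromatic ring of compound 1 and changes one group: (1-(methoxymethyl)-1-methylethyl)amino in place of piperidin-1-yl on an aromatic carbon. Compound 2 carries an open-chain amino group at the same position and shows the lower number, which hints that such a change may help, though its other differences cloud the picture. The step from compound 1 to compound 3 is expected to be a moderate decrease, a 2.3-fold lower number from compound 1 to compound 3 (0.36 log units; beyond the scatter). Compound 3 is therefore estimated at 20 nM, within a range of 6 nM to 65 nM.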

Compound 3, inhibition constant: 195 nM
Compound 3: middle estimate off by 9.8-fold (0.99 log units), on the low side, outside the stated range (above it).
By their numbers in this assay, from the lowest: compound 2; then compound 1; then compound 3.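

With the shared core and the aromatic ring held fixed, placing (1-(methoxymethyl)-1-methylethyl)amino in place of piperidin-1-yl gives a 4.2-fold higher number from compound 1 to compound 3 (0.63 log units; beyond the scatter) in this assay, so at this position the change costs inhibition rather than adding to it. An open-chain amino group at this position therefore does not lower the number by itself, and the low number of compound 2 cannot be credited to that feature alone. No measurement at hand explains why the number rises.

The entering group loses the ring and gains an oxygen and a hydrogen-bond donor all at once, so this single step cannot show which of these differences matters. From the compounds shown here alone, how a tert-butylamino group, which lacks the methoxy part, or a morpholin-4-yl group, which keeps a ring and adds an oxygen, would fare on the core of compound 1 remains open.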